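Swapping chloro for sulfanyl on a weakly active purine-like scaffold

The source may hold more compounds than are shown below. What is called first, only, known or untested is meant among the compounds shown, and "the series" means these compounds.

Of the compounds shown here, three have been measured in a functional assay on CCRF-CEM cells (Homo sapiens) for inhibition; on this read-out higher numbers stand for weaker inhibition and lower numbers for stronger inhibition. Compound 1 `CC(=O)OC(C)n1cnc2c(Cl)nc(I)nc21` gives 15900 nM, compound 2 `CC(=O)OCCOn1cnc2c(Cl)nc(I)nc21` gives 11000 nM, and compound 3 `CC(=O)OC(C)n1cnc2c(Cl)nc(F)nc21` gives 44000 nM, the highest of the three numbers. Among the measured compounds shown here, the only single change among them, a 2.8-fold higher number from compound 1 to compound 3 (0.44 log units; beyond the scatter), concerns the fluoro group and does not touch the chloro group. Compound 4 `CC(=O)OC(C)n1cnc2c(S)nc(F)nc21` differs from compound 3 by sulfanyl in place of chloro on an aromatic carbon. For the measured compounds named here, no measured step covers this position, so there is no basis in this assay for expecting a shift in either direction. Compound 4 is therefore estimated to give 44000 nM, within 12000 nM to 160000 nM, a step of no change at the digits printed from compound 3 to compound 4 (within the scatter) that is expected to stay within the scatter.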

Compound 4, half-maximal inhibitory concentration: > 500000 nM
Compound 4: no number, only a limit; the forecaster's own chance of this, stated with the estimate: 30%; middle value at least 11-fold (1.05 log units) away from the limit.
By their numbers in this assay, from the lowest: compounds 2 and 1 (each within the scatter of the next); then compound 3. At a limit, above all of these: compound 4.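

Sulfanyl in place of chloro on the aromatic carbon next to the ring nitrogen gives an at least 11-fold higher number from compound 3 to compound 4 (1.05 log units; beyond the scatter), the first measured step at this position. It shows that this position is far from indifferent in this series, and that this change costs much of the weak inhibition seen with chloro. Compound 4 gives no number in this assay, only a limit: the limit of > 500000 nM in this assay, at which 1 of the 4 values shown sits.

The compounds shown leave open whether another group at this position, such as an amine or a methoxy group, would keep inhibition. Also open, from the compounds shown here alone, is whether sulfanyl would cost as much alongside the iodo group of compound 1.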